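The compounds below may be only part of what the source reports. "The series", "measured", "known", "first", "only" and "open" are said of these compounds alone.

Compound 1 `COC(=O)C1=C(C)N(C)C(=O)NC1c1ccco1`, compound 2 `CC1=C(C(=O)OCC(C)C)C(c2ccco2)NC(=O)N1C` and compound 3 `CC1=C(C(=O)OCc2ccccc2)C(c2ccco2)NC(=O)N1C` share one core and differ only in the group on the saturated chain carbon bound to an oxygen next to a carbonyl group. In an assay on membranes from HeLa cells for displacement of a labelled ligand from adenosine receptor A3 (Homo sapiens), read by scintillation counting, with a stated time of 180 min, tested at 1 uM (on this read-out lower numbers stand for less inhibition and higher numbers for more inhibition at the one concentration tested (going by the name of the read-out)), compound 1 gives 9%, compound 2 gives 23% and compound 3 gives 11%. Compound 3 thus stands second highest of the three numbers; its nearest neighbour is compound 1, and the gap a number 2 percentage points higher from compound 1 to compound 3 (within the scatter) lies within the scatter, while a number 12 percentage points lower from compound 2 to compound 3 (beyond the scatter) is a modest step beyond it. The remaining measured step, a number 14 percentage points higher from compound 1 to compound 2 (beyond the scatter), is a modest one in the other direction.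

Compound 4 `CC1=C(C(=O)OCc2ccccc2)C(c2ccoc2)NC(=O)N1C` keeps the ester of compound 3 and carries furan-3-yl in place of furan-2-yl on a saturated ring carbon. Among the measured compounds shown here, none of the three measured steps concerns the saturated ring carbon; all three alter the ester group, so no measured step bears on this change. With nothing to draw on, compound 4 is expected to stay close to compound 3, with an estimated step of no change at the digits printed from compound 3 to compound 4 (within the scatter) that should lie within the scatter. Compound 4 is therefore estimated at 11% in this assay, with a range from 0% to 25%.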

Compound 4, a percentage reported as inhibition, at one concentration (the size of the read-out at that concentration, not a potency): 25%
Compound 4: middle estimate off by 14 percentage points, on the low side, within the range that was stated.
By their numbers in this assay, from the lowest: compounds 1 and 3 (each within the scatter of the next); then compounds 2 and 4 (each within the scatter of the next).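

In this assay, the group on the saturated ring carbon is shown to matter: a number 14 percentage points higher from compound 3 to compound 4 (beyond the scatter), with furan-3-yl in place of furan-2-yl. The two compounds have the same atoms joined differently, so the point of attachment of the furan alone separates their numbers. The earlier compounds all carried furan-2-yl and differed only in the ester, so they could not show this, and nothing measured here accounts for the step.

On these data alone, it remains open whether furan-3-yl would have a similar effect with the esters of compound 1 and compound 2, as compound 4 carries only the ester of compound 3. Also open, as far as these compounds go, is how a thiophene or a pyridine ring would read on the same saturated ring carbon.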